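The compounds below may be only part of what the source reports. "The series", "measured", "known", "first", "only" and "open" are said of these compounds alone.

Measured so far:
compound 1 `COc1ccccc1NCC(=O)Oc1ccc2c(C)cc(=O)oc2c1` — 19.4%
compound 2 `Cc1cc(=O)oc2cc(OC(=O)CNc3ccc(Cl)cc3)ccc12` — 16.1%
compound 3 `Cc1cc(=O)oc2cc(OC(=O)CNc3ccc([N+](=O)[O-])cc3)ccc12` — 23.7%

In a functional assay on the whole organism (strain Wistar albino) for inhibition, with Rattus norvegicus as the target, read by paw edema, with stated times of 30 min and 4 h, at a dose of 20 mg/kg by the oral route (a lower number here means less inhibition, a higher number more inhibition at the dose given (going by the name of the read-out)), compound 2 gives 16.1%. Compound 1 and compound 3 both sit within the scatter of it, so none of the three is separated from the others.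

Compound 4 `Cc1cc(=O)oc2cc(OC(=O)CNN3C=NNC3)ccc12` differs from compound 2 in one place: a group of 5 heavy atoms (2 carbon, 3 nitrogen; one five-membered non-aromatic ring with 3 hetero atoms) in place of a group of 7 heavy atoms (6 carbon, 1 chlorine; one six-membered aromatic ring of carbon only), on an amine nitrogen. The step that bears most on this is the exchange of the group on the amine nitrogen, a number 3.3 percentage points lower from compound 1 to compound 2 (within the scatter); the exchange on the aromatic carbon, a number 7.6 percentage points higher from compound 2 to compound 3 (within the scatter), also stayed within the scatter. Neither change to the group on the amine nitrogen has moved the number beyond the scatter.

Compound 4 is therefore expected to give about 20% in this assay, between 10% and 30%. This corresponds to an expected a number 3.9 percentage points higher from compound 2 to compound 4 (within the scatter), within the scatter.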

Compound 4, a percentage reported as inhibition, in the whole organism at one dose (the size of the read-out at that dose, not a potency): 22.2%
Compound 4: middle estimate off by 2.2 percentage points, on the low side, and the stated range covers the measured number.
By their numbers in this assay, from the lowest: compounds 2, 1, 4 and 3 (each within the scatter of the next).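

In this assay, a ring with no aromatic carbon on the amine nitrogen gives a number 6.1 percentage points higher from compound 2 to compound 4 (within the scatter) and a number 2.8 percentage points higher from compound 1 to compound 4 (within the scatter), so the five-membered non-aromatic ring with 3 hetero atoms is not separated from either aromatic group. At this position, then, an aromatic ring of carbon only is not needed to keep the read-out at this level at the dose given. No measurement here gives a reason for this. On these data alone, whether a carboxylic acid or a longer chain on the amine nitrogen would move the number beyond the scatter remains open.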